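The source may report more compounds than this note shows. Statements on the series, on what has been measured and on what is new or still open speak of the compounds shown alone.

Measured compounds:
compound 1 `CCS(=O)(=O)Nc1cc(-c2ccc3ncnc(Nc4ccc(F)c(C(=O)OC)c4)c3c2)cnc1OC`, which in a functional assay on BT-549 cells (Homo sapiens) for cytotoxicity, read by sulforhodamine B assay, with a stated time of 72 h (a higher number here means a weaker inhibitor, a lower number a stronger inhibitor), gives 2740 nM
compound 2 `CCS(=O)(=O)Nc1cc(-c2ccc3ncnc(Nc4ccc(F)nc4)c3c2)cnc1OC`, which in this assay gives 4780 nM

Going by the values given here, compound 2 holds the higher of the two numbers in this assay; the only neighbour is compound 1, and the step of a 1.7-fold higher number from compound 1 to compound 2 (0.24 log units; within the scatter) lies within the scatter. Compound 3 `CCS(=O)(=O)Nc1cc(-c2ccc3ncnc(Nc4ccc(OC)nc4)c3c2)cnc1OC` differs from compound 2 by methoxy in place of fluoro on an aromatic carbon. Among the compounds with values here, no measured step changes this group; the one measured step, a 1.7-fold higher number from compound 1 to compound 2 (0.24 log units; within the scatter), exchanges the whole aryl and is within the scatter. No step beyond the scatter is therefore expected. Compound 3 is estimated at 4000 nM (range 1800 nM to 9000 nM). The expected step is a 1.2-fold lower number from compound 2 to compound 3 (0.08 log units; within the scatter).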

Compound 3, half-maximal inhibitory concentration: 3490 nM
Beside the measured number, compound 3's estimate is 1.1-fold (0.06 log units) above it; the measured number falls inside the stated range.
By their numbers in this assay, from the lowest: compounds 1, 3 and 2 (each within the scatter of the next).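

In this assay, methoxy in place of fluoro on the aromatic carbon next to the ring nitrogen stays within the scatter (a 1.4-fold lower number from compound 2 to compound 3 (0.14 log units; within the scatter)), so the larger of these two groups shifts the number no more than repeat measurements would. 6-methoxypyridin-3-yl in place of the whole 4-fluoro-3-(methoxycarbonyl)phenyl also stays within the scatter (a 1.3-fold higher number from compound 1 to compound 3 (0.11 log units; within the scatter)). Nothing available bears on the reason for these readings.

As far as these compounds go, whether an amine, a carboxylic acid or a longer chain such as butoxy on this carbon would give a step beyond the scatter remains open.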